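Swapping the sulfonamide aryl group in a dopamine receptor series

A few compounds are considered here, and "the series" means these few. Any claim that something is new, unique, unknown or untested is made for them only; others in the source may bear on it.

Measured so far:
compound 1, `CCCN(CC[C@H]1CC[C@H](NC(=O)/C=C/c2ccc(F)cc2)CC1)[C@H]1CCc2nc(N)sc2C1`, 1 nM
compound 2, `CCCN(CC[C@H]1CC[C@H](NC(=O)/C=C/c2cccc(Cl)c2)CC1)[C@H]1CCc2nc(N)sc2C1`, 1.2 nM
compound 3, `CCCN(CC[C@H]1CC[C@H](NS(=O)(=O)c2cccc3ccccc23)CC1)[C@H]1CCc2nc(N)sc2C1`, 1.5 nM

In an assay on brain for displacement of a labelled ligand from D(3) dopamine receptor (Rattus norvegicus) (on this read-out higher numbers stand for weaker inhibition and lower numbers for stronger inhibition), compound 3 gives the highest of the three numbers, yet all three sit within the usual scatter of one another. Compound 4, `CCCN(CC[C@H]1CC[C@H](NS(=O)(=O)c2ccc(OC)cc2)CC1)[C@H]1CCc2nc(N)sc2C1`, is not yet measured. It differs from compound 3 by 4-methoxyphenyl in place of naphthalen-1-yl on a sulfonyl sulfur. Among the compounds with values here, the only measured step, an exchange of one aryl group for another on the amide side, was a 1.2-fold higher number from compound 1 to compound 2 (0.08 log units; within the scatter). The change here is likewise an aryl swap, though on a sulfonyl sulfur and with a larger loss of ring atoms, so a small step is expected, estimated as a 2.7-fold higher number from compound 3 to compound 4 (0.43 log units; beyond the scatter) in this assay. Compound 4 is therefore expected at about 4 nM, within 1.2 nM to 14 nM.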

Compound 4, inhibition constant: 0.78 nM
Compound 4: the middle estimate sits 5.1-fold (0.71 log units) above what was measured, and the stated range ends above it.
By their numbers in this assay, from the lowest: compounds 4, 1, 2 and 3 (each within the scatter of the next).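

In this assay, the single ring of 4-methoxyphenyl on the sulfonyl sulfur does as well as the two rings of naphthalen-1-yl (a 1.9-fold lower number from compound 3 to compound 4 (0.28 log units; within the scatter)), so the second ring is not needed to stay within the scatter here. Exchanging the carbonyl-linked arms for (4-methoxyphenyl)sulfonyl on the amine nitrogen also stays within the scatter (a 1.5-fold lower number from compound 2 to compound 4 (0.19 log units; within the scatter); a 1.3-fold lower number from compound 1 to compound 4 (0.11 log units; within the scatter)). Nothing available explains this tolerance. Still open, as far as these compounds go, is how the number responds to a plain methyl on the sulfonyl sulfur, or to an aryl group carrying an amine or a carboxylic acid.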